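One Methyl Less on the Side Chain of Compound 1

The source may hold more compounds than are shown below. What is called first, only, known or untested is meant among the compounds shown, and "the series" means these compounds.

Of the compounds shown here, three have so far been measured in a functional assay on L1210 cells (Mus musculus) for antiproliferative activity; a higher number here means a more potent compound, by a factor of ten per unit of this negative logarithm, a lower number a less potent compound. Compound 1 `CC(C)Cc1nc(/N=N/N(C)C)c(C(N)=O)[nH]1` gives 3.53. Compound 2 `CCCN(C)/N=N/c1nc[nH]c1C(N)=O` gives 3.58, and compound 3 `CC(C)CN(C)/N=N/c1nc[nH]c1C(N)=O` gives 3.51. Compound 3 and compound 2 differ in a single place: hydrogen in place of methyl on a saturated chain carbon bound to two saturated chain carbons. The step that this change made is a number 0.07 log units higher from compound 3 to compound 2 (within the scatter), so the two numbers cannot be told apart. Compound 1 and compound 3 are built on different cores, and the difference between the two cores is not broken down here; what the two values show is that they sit close together, within the usual scatter of this assay.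

Compound 4 `CCCc1nc(/N=N/N(C)C)c(C(N)=O)[nH]1` has not yet been measured. For the measured compounds named here, it differs from compound 1 by hydrogen in place of methyl on a saturated chain carbon bound to two saturated chain carbons, which is the same change, at the same kind of place, as the one between compound 3 and compound 2. Going by the values given here, the only guide to its size is that earlier step, and since that step was a number 0.07 log units higher from compound 3 to compound 2 (within the scatter), the step from compound 1 to compound 4 is expected to be a number 0.05 log units higher from compound 1 to compound 4 (within the scatter), an expectation that rests on the step of a number 0.07 log units higher from compound 3 to compound 2 (within the scatter) alone and on just one such pair. On that basis compound 4 is estimated to give 3.58 in this assay, with the expected range running from 3.25 to 3.9.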

Compound 4, logarithm of the reciprocal of the active concentration, log(1/C): 3.42
Estimate against measurement, compound 4: 0.16 log units above, and the stated range covers the measured number.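

In this assay, hydrogen in place of methyl on a saturated chain carbon bound to two saturated chain carbons, which turns isobutyl into propyl on the core of compound 1, comes out as a number 0.11 log units lower from compound 1 to compound 4 (within the scatter), and the two numbers cannot be told apart. Set beside the same change on the other core, this step gives no sign that the core alters the outcome: the same change on two cores in this assay, a number 0.07 log units higher (within the scatter) from compound 3 to compound 2 and a number 0.11 log units lower (within the scatter) from compound 1 to compound 4, 0.18 log units apart, within the scatter of two such steps. This supports carrying the change between these two cores only in a narrow sense, since neither step rises above the scatter and each core supplies a single pair, so a real but small difference between the cores would go unseen, and the agreement does not show that a change with a larger effect would carry over in the same way.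

The compounds shown have only isobutyl and propyl as the varied chains, which leaves open whether a longer chain, such as hexyl, would move the number beyond the scatter on either core. From the compounds shown here alone, it also remains open whether an amine or a carboxylic acid at the end of such a chain would do so, and whether any step of that kind would be the same on both cores.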